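The source may hold more compounds than are shown below. What is called first, only, known or untested is meant among the compounds shown, and "the series" means these compounds.

Among the compounds with values here, compound 3 `O=C1c2c[n+]([O-])c3ccccc3c2C(=O)c2c1c1ccccc1n2Cc1cn(CC(O)CO)nn1` is one of three compounds measured in a functional assay on SH-SY5Y cells (Homo sapiens) for cytotoxicity, read by MTT assay, with a stated time of 72 h; on this read-out lower numbers stand for stronger inhibition and higher numbers for weaker inhibition. For compound 3 this assay gives only a limit, > 1000 nM, and not a number. Compound 1 `O=C1c2c[n+]([O-])c3ccccc3c2C(=O)c2c1c1ccccc1n2Cc1cn([C@H]2O[C@H](CO)[C@@H](O)[C@H]2O)nn1` gives 1340 nM in this assay, and compound 2 `O=C1c2c[n+]([O-])c3ccccc3c2C(=O)c2c1c1ccccc1n2CCCCn1ccnc1` gives 130 nM. The step that the limit leaves unreadable from compound 1 to compound 3 cannot be sized because of the limit of > 1000 nM in this assay, at which 1 of the 3 values shown sits. The step of an at least 7.6-fold higher number from compound 2 to compound 3 (0.88 log units; beyond the scatter) can at least be read as a minimum, and it places compound 3 at the weak end of what has been measured.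

Compound 4 `O=C1c2c[n+]([O-])c3ccccc3c2C(=O)c2c1c1ccccc1n2CCCCN1CCCCC1` has not yet been measured. It differs from compound 3 in one place: 3-(piperidin-1-yl)propyl in place of 1-(2,3-dihydroxypropyl)-1H-1,2,3-triazol-4-yl on a saturated chain carbon bound to an aromatic nitrogen. Within the data shown here, of the measured steps, only the one from compound 2 to compound 3 bears on this change, since the 3-(piperidin-1-yl)propyl group of compound 4 resembles the 3-(1H-imidazol-1-yl)propyl group of compound 2 far more than the 1-(2,3-dihydroxypropyl)-1H-1,2,3-triazol-4-yl group of compound 3. A return toward the number of compound 2 is therefore expected, and in this assay the expected step is an at least 5.0-fold lower number from compound 3 to compound 4 (0.69 log units; beyond the scatter). Compound 4 is thus estimated to give about 200 nM in this assay, with a range from 60 nM to 700 nM.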

Compound 4, half-maximal inhibitory concentration: 230 nM
The estimate for compound 4 lay 1.2-fold (0.06 log units) below the measured number; the range from low to high includes it.
By their numbers in this assay, from the lowest: compounds 2 and 4 (each within the scatter of the next); then compound 1.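

Setting 3-(piperidin-1-yl)propyl in place of 1-(2,3-dihydroxypropyl)-1H-1,2,3-triazol-4-yl, on a saturated chain carbon bound to an aromatic nitrogen, gives in this assay an at least 4.3-fold lower number from compound 3 to compound 4 (0.63 log units; beyond the scatter), a size that can be read only as a minimum: the limit of > 1000 nM in this assay, at which 1 of the 4 values shown sits.

The exchange of 1H-imidazol-1-yl for piperidin-1-yl on the same chain gives a 1.8-fold higher number from compound 2 to compound 4 (0.25 log units; within the scatter), so a five-membered aromatic ring and a six-membered non-aromatic ring at the chain end cannot be told apart in this assay. Until now only one such chain end had a number, and compound 4 shows that a second ring type at the end of the chain also stays clear of the limit seen for compound 3.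

The step to compound 4 changes the whole group at once, so the compounds shown do not separate the contribution of the triazole ring from that of the two hydroxyl groups or of the chain. They also leave open whether a shorter or longer chain, an open-chain amine such as dimethylamino, or a morpholin-4-yl ring at the chain end would keep the number of compound 4.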